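The source may hold more compounds than are shown below. What is called first, only, known or untested is meant among the compounds shown, and "the series" means these compounds.

Compound 1 `CCC(C)(C)Cc1c[nH]c(CCc2ccc(-c3ccccc3O)cc2)n1` gives 31 nM in an assay on isolated protein for binding affinity to Bombesin receptor subtype-3 (Homo sapiens) (a lower number here means a stronger inhibitor, a higher number a weaker inhibitor), the lower of the two numbers recorded so far. Compound 2 `CCC(C)(C)Cc1c[nH]c(CCc2ccc(-c3ccccc3OCC(=O)O)cc2)n1` gives 103 nM in this assay; the step of a 3.3-fold higher number from compound 1 to compound 2 (0.52 log units; beyond the scatter) came from carboxymethyl in place of hydrogen on an oxygen on an aromatic ring. Compound 3 `CCC(C)(C)Cc1c[nH]c(CCc2ccc(-c3ccccc3OCc3cnn[nH]3)cc2)n1` differs from compound 1 by (1H-1,2,3-triazol-5-yl)methyl in place of hydrogen on an oxygen on an aromatic ring. For the measured compounds named here, the only step that bears on this change is the one from compound 1 to compound 2, and it was modest; a change at the same oxygen is therefore expected to cost a comparable modest step, a 2.6-fold higher number from compound 1 to compound 3 (0.41 log units; beyond the scatter). For compound 3 the estimate in this assay is 80 nM, with a range from 25 nM to 250 nM.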

Compound 3, half-maximal inhibitory concentration: 83 nM
Compound 3: middle estimate off by 1.0-fold (0.02 log units), on the low side; low and high end bracket the measured number.
By their numbers in this assay, from the lowest: compound 1; then compounds 3 and 2 (each within the scatter of the next).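

At this oxygen a second group, (1H-1,2,3-triazol-5-yl)methyl, also raises the number in this assay (a 2.7-fold higher number from compound 1 to compound 3 (0.43 log units; beyond the scatter)), so the free hydroxy stays lowest of the three. The two capped side chains are not separated when 1H-1,2,3-triazol-5-yl stands in place of carboxy (a 1.2-fold lower number from compound 2 to compound 3 (0.09 log units; within the scatter)). No measurement here accounts for either step. Open, on these data alone, is whether a plain methyl on this oxygen would also raise the number, or whether the step depends on the group carried by the methylene. As far as these compounds go, an amine at the end of a longer chain on this oxygen also remains untested here.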